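A few compounds are considered here, and "the series" means these few. Any claim that something is new, unique, unknown or untested is made for them only; others in the source may bear on it.

Compound 1 `CCCN(CC[C@H]1CC[C@H](NC(=O)/C=C/c2ccccc2Cl)CC1)[C@H]1CCc2nc(N)sc2C1` is the starting point here. In an assay on brain for displacement of a labelled ligand from D(3) dopamine receptor (Rattus norvegicus) (on this read-out higher numbers stand for weaker inhibition and lower numbers for stronger inhibition), compound 1 gives 1.2 nM, the lowest number among the three measured compounds, although the gap to compound 2 lies within the usual scatter. Compound 2 `CCCN(CC[C@H]1CC[C@H](NC(=O)c2ccc3ccccc3n2)CC1)[C@H]1CCc2nc(N)sc2C1` gives 1.6 nM in this assay, and compound 3 `CCCN(CC[C@H]1CC[C@H](NC(=O)c2cccc3cnccc23)CC1)[C@H]1CCc2nc(N)sc2C1` gives 5.9 nM.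

The step to compound 4 `CCCN(CC[C@H]1CC[C@H](NC(=O)c2ccc(-n3ccnc3)cc2)CC1)[C@H]1CCc2nc(N)sc2C1` changes only the group on the carbonyl carbon: 4-(1H-imidazol-1-yl)phenyl in place of 2-(2-chlorophenyl)ethenyl on a carbonyl carbon. For the measured compounds named here, two measured steps bear on it, since each also swaps the 2-(2-chlorophenyl)ethenyl group for an aromatic ring system at the same place. Replacing it with quinolin-2-yl gave a 1.3-fold higher number from compound 1 to compound 2 (0.12 log units; within the scatter), whereas replacing it with isoquinolin-5-yl gave a 4.9-fold higher number from compound 1 to compound 3 (0.69 log units; beyond the scatter). So exchanging this group for a flat aromatic piece has cost nothing or a modest amount; no measured case shows a gain. For the 4-(1H-imidazol-1-yl)phenyl group the expectation is therefore a small to modest rise in the number, about a 2.9-fold higher number from compound 1 to compound 4 (0.46 log units; beyond the scatter), with a chance that it stays within the scatter. The estimated value for compound 4 in this assay is 3.5 nM, with a likely range from 1.2 nM to 12 nM.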

Compound 4, inhibition constant: 1.9 nM
The estimate for compound 4 lay 1.8-fold (0.27 log units) above the measured number; measured number inside the range.
By their numbers in this assay, from the lowest: compounds 1, 2 and 4 (each within the scatter of the next); then compound 3.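

In this assay, the 4-(1H-imidazol-1-yl)phenyl group, with its five-membered aromatic ring holding two hetero atoms, fits this place on the carbonyl carbon as well as the earlier groups that gave the lowest numbers: the change is a 1.6-fold higher number from compound 1 to compound 4 (0.20 log units; within the scatter), and against the quinolin-2-yl group it is a 1.2-fold higher number from compound 2 to compound 4 (0.07 log units; within the scatter). The swap from compound 1 removes the chlorine and the double bond outside aromatic rings and adds hydrogen-bond acceptors, yet the number does not move beyond the scatter. The result also sets compound 3 further apart, with a 3.1-fold lower number from compound 3 to compound 4 (0.49 log units; beyond the scatter), so the isoquinolin-5-yl group now differs beyond the scatter from all three other groups.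

Nothing available here explains why compound 3 stands apart or why the other three groups sit so close together. From the compounds shown here alone, it also remains open whether this place needs an aromatic ring at all, since a plain hexyl chain, a cyclohexyl ring or a group ending in a carboxylic acid or an amine could give quite different numbers.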